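The source may report more compounds than this note shows. Statements on the series, on what has been measured and on what is new or still open speak of the compounds shown alone.

Measured so far:
compound 1, `O=S(=O)(/C=C/c1ccc(F)cc1Cl)Cc1ccc(Nc2ncnc3ccccc23)cc1`: in a functional assay on SK-OV-3 cells (Homo sapiens) (on this read-out higher numbers stand for weaker inhibition of growth and lower numbers for stronger inhibition of growth), compound 1 gives 44000 nM
compound 2, `O=S(=O)(/C=C/c1ccc(C(F)(F)F)cc1F)Cc1ccc(Nc2ncnc3ccccc23)cc1`: compound 2 gives 39000 nM
compound 3, `O=S(=O)(/C=C/c1ccc(C(F)(F)F)cc1F)Cc1ccc(Nc2ncnc3cc(Cl)ccc23)cc1`: for compound 3 the assay reports only a limit, > 100000 nM, and no number.

Compound 4 `O=S(=O)(/C=C/c1ccc(F)cc1Cl)Cc1ccc(Nc2ncnc3cc(Cl)ccc23)cc1` has not yet been measured. The core of compound 3 and compound 4 differs from that of compound 1 and compound 2 by chloro in place of hydrogen on an aromatic carbon. That change gave an at least 2.5-fold higher number from compound 2 to compound 3 (0.40 log units; beyond the scatter), with compound 3 sitting at the limit of > 100000 nM in this assay, at which 1 of the 3 values shown sits. Compound 4 differs from compound 3 by 2-chloro-4-fluorophenyl in place of 2-fluoro-4-(trifluoromethyl)phenyl on a double-bonded chain carbon bound to a double-bonded chain carbon, the same change as 2-chloro-4-fluorophenyl in place of 2-fluoro-4-(trifluoromethyl)phenyl on a double-bonded chain carbon bound to a double-bonded chain carbon, which gave a 1.1-fold higher number from compound 2 to compound 1 (0.05 log units; within the scatter). The step from compound 3 to compound 4 is therefore expected to be a step that the limit leaves unreadable from compound 3 to compound 4, resting on that earlier step and on the limit for compound 3. Compound 4 is expected to give about 150000 nM in this assay, most likely again reported only as a limit, within 60000 nM to 400000 nM.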

Compound 4, concentration for 50% growth inhibition: > 100000 nM
Compound 4: a limit, no number (the forecaster's own chance of this, stated with the estimate: 80%); the middle value lies beyond the limit too.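

In this assay compound 4 is reported only as a limit, > 100000 nM. Chloro in place of hydrogen on an aromatic carbon gives an at least 2.2-fold higher number from compound 1 to compound 4 (0.35 log units; beyond the scatter), so the change points the same way on both cores: the same change on two cores in this assay, an at least 2.5-fold higher number (0.40 log units; beyond the scatter) from compound 2 to compound 3 and an at least 2.2-fold higher number (0.35 log units; beyond the scatter) from compound 1 to compound 4; the limit leaves it open whether they differ The true size of the change on either core stays unknown, and the step from compound 3 to compound 4 cannot be read, so this does not show whether the swap of 2-fluoro-4-(trifluoromethyl)phenyl for 2-chloro-4-fluorophenyl carries over to the chlorinated core: the limit of > 100000 nM in this assay, at which 2 of the 4 values shown sit.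

The compounds shown leave open how fluoro, methoxy or an amine in place of that chloro would read out in this assay.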